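Compound 3 Swaps a Group: Which Way Next?

This account rests on a few compounds, and the source may have more. Where it says the series, first, only, none or still open, it means among the compounds named here.

compound 1 `CC(C)c1cc(Cl)cc(C(C)C)c1O` gives 5.34 
compound 2 `CC(C)c1cc(C(=O)c2ccccc2)cc(C(C)C)c1O` gives 5.91 
compound 3 `CC(C)c1cc(CN(C)C)cc(C(C)C)c1O` gives 2.5 

These numbers come from a physicochemical assay for lipophilicity (a lower number here means a more polar compound, a higher number a more lipophilic compound), and compound 3 stands lowest of the three, with compound 1 nearest and compound 2 furthest, both clear of the scatter. Compound 4 `CC(C)c1cc(NS(C)(=O)=O)cc(C(C)C)c1O` is still unmeasured. It differs from compound 3 in one place, and the count of that change is methanesulfonamido in place of (dimethylamino)methyl on an aromatic carbon in words, methanesulfonamido in place of (dimethylamino)methyl on an aromatic carbon. Within the data shown here, the only measured step at this carbon is a number 2.84 log units lower from compound 1 to compound 3 (beyond the scatter) and it is large, so a swap here can shift the number substantially. Among the measured compounds shown here, no measured compound carries methanesulfonamido, so that step shows the possible scale and not the answer. For the measured compounds named here, with compound 3 at 2.5 as the lowest number so far, a rise of moderate size seems likelier than a further fall. The expected change is a number 1.00 log units higher from compound 3 to compound 4 (beyond the scatter) as an estimate. Compound 4 is therefore expected at 3.5 with an estimated range from 2.8 to 4.2 in this assay once it is measured.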

Compound 4, partition coefficient: 3.14
Beside the measured number, compound 4's estimate is 0.36 log units above it; low and high end bracket the measured number.
By their numbers in this assay, from the lowest: compound 3; then compound 4; then compound 1; then compound 2.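

In this assay, methanesulfonamido in place of (dimethylamino)methyl on this aromatic carbon gives a number 0.64 log units higher from compound 3 to compound 4 (beyond the scatter), so this second swap moves the number far less than the earlier change from chloro did. Measured against chloro, the same group gives a number 2.20 log units lower from compound 1 to compound 4 (beyond the scatter), which means that two quite different groups, methanesulfonamido and (dimethylamino)methyl, now both stand well under chloro at this carbon, with the methanesulfonamido compound the higher of the two. Nothing measured here explains why the number moves in this way.

On these data alone, it stays open whether a carboxylic acid or a primary amine at this carbon would fall under compound 3 or land closer to compound 4. As far as these compounds go, it is equally open how far a longer chain on the sulfonyl group, such as ethanesulfonamido, would shift the number from compound 4.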